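Aminoquinoline series: removing one chloro from compound 3

The source may report more compounds than this note shows. Statements on the series, on what has been measured and on what is new or still open speak of the compounds shown alone.

Three analogues share one core and differ only in the aryl group on the amine nitrogen. Compound 1 `CC(C)c1ccc(Nc2ccc3c(OCCCN4CCN(C)CC4)cccc3n2)cc1` gives 9950 nM in a functional assay on cells (Panel breast (Carcinoma cell lines), Homo sapiens) for inhibition, read by sulforhodamine B assay, with a stated time of 48 h; on this read-out lower numbers stand for stronger inhibition of growth and higher numbers for weaker inhibition of growth. Compound 2 `CN1CCN(CCCOc2cccc3nc(Nc4ccc(F)c(F)c4)ccc23)CC1` gives 3140 nM, and compound 3 `CN1CCN(CCCOc2cccc3nc(Nc4cc(Cl)cc(Cl)c4)ccc23)CC1` gives 2060 nM, the lowest of the three numbers, though compound 2 lies within the scatter of it. The measured steps are a 3.2-fold lower number from compound 1 to compound 2 (0.50 log units; beyond the scatter), a 4.8-fold lower number from compound 1 to compound 3 (0.68 log units; beyond the scatter) and a 1.5-fold lower number from compound 2 to compound 3 (0.18 log units; within the scatter).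

Compound 4 `CN1CCN(CCCOc2cccc3nc(Nc4cccc(Cl)c4)ccc23)CC1` is not yet measured. It differs from compound 3 by hydrogen in place of chloro on an aromatic carbon, that is, 3,5-dichlorophenyl to 3-chlorophenyl, the hydrogen entering on an aromatic carbon meta to a chloro group and meta to a large group.

For the measured compounds named here, no measured step removes a single chloro, so none bears on this change directly. The nearest guide is the step from compound 2 to compound 3, where two ring halogens were exchanged for two others and the numbers stayed within the scatter; aryl substitution changes among these compounds moved the read-out only modestly at most. For compound 4 the expected step is therefore a 1.6-fold higher number from compound 3 to compound 4 (0.19 log units; within the scatter), a slight drift toward a higher number, not clearly beyond the scatter. Compound 4 is estimated at 3200 nM, within 1300 nM to 8000 nM.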

Compound 4, concentration for 50% growth inhibition: 1850 nM
Compound 4: the middle estimate sits 1.7-fold (0.24 log units) above what was measured, and the stated range covers the measured number.
By their numbers in this assay, from the lowest: compounds 4, 3 and 2 (each within the scatter of the next); then compound 1.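

In this assay, hydrogen in place of chloro on an aromatic carbon, meta to a chloro group and meta to a large group, leaves the read-out within the scatter (a 1.1-fold lower number from compound 3 to compound 4 (0.05 log units; within the scatter)), so at this position the second chloro of the 3,5-dichlorophenyl group is not needed to keep the number in this range. For the compounds shown here, the 3-chlorophenyl group of compound 4 also stays within the scatter of the 3,4-difluorophenyl group (a 1.7-fold lower number from compound 2 to compound 4 (0.23 log units; within the scatter)), while only the step from the 4-isopropylphenyl group lies beyond it (a 5.4-fold lower number from compound 1 to compound 4 (0.73 log units; beyond the scatter)), and that step is modest. No supporting data bear on the reason for this flat response.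

On these data alone, whether the remaining chloro contributes at all stays open, and an unsubstituted phenyl group on the amine nitrogen would settle that. Also open, as far as these compounds go, is whether this position stays as flat with something other than chloro or hydrogen, such as a methoxy group, an amine or a carboxylic acid, or whether the narrow spread holds only among halogens.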